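One group swap on the amide nitrogen of compound 2

The source may hold more compounds than are shown below. What is called first, only, known or untested is meant among the compounds shown, and "the series" means these compounds.

Compound 1 `CC(C)n1ncc2c(C(=O)Nc3cccc(C(N)=O)c3)cc(-c3cccs3)nc21` gives 25000 nM
Compound 2 `CC(C)n1ncc2c(C(=O)Nc3ccccc3F)cc(-c3cccs3)nc21` gives 50000 nM

In an ADME assay on LLC-MK2 cells (Macaca mulatta) for cytotoxicity, read by spectrophotometry and crystal violet staining, with a stated time of 4 days (on this read-out lower numbers stand for higher toxicity in this test and higher numbers for lower toxicity in this test), compound 2 (50000 nM) lies within the scatter of compound 1 (25000 nM). Compound 3 `CC(C)n1ncc2c(C(=O)Nc3ccc(F)cn3)cc(-c3cccs3)nc21` carries 5-fluoropyridin-2-yl in place of 2-fluorophenyl on an amide-type nitrogen. Among the measured compounds shown here, only one measured step bears on this: the exchange on that same nitrogen gave a 2.0-fold higher number from compound 1 to compound 2 (0.30 log units; within the scatter) and so no change beyond the scatter is expected here. The expected size is a 1.3-fold lower number from compound 2 to compound 3 (0.10 log units; within the scatter) in this assay with no firm direction. Compound 3 is estimated at 40000 nM (expected range 15000 nM to 90000 nM).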

Compound 3, half-maximal cytotoxic concentration: > 200000 nM
Compound 3: only a limit was reported (the forecaster's own chance of this, stated with the estimate: 25%); middle value at least 5.0-fold (0.69 log units) from the limit.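

Compound 1 and compound 2 stayed within the scatter of each other, but this position can clearly move the reading in this assay. With 5-fluoropyridin-2-yl on the amide-type nitrogen, the result is an at least 4.0-fold higher number from compound 2 to compound 3 (0.60 log units; beyond the scatter) and an at least 8.0-fold higher number from compound 1 to compound 3 (0.90 log units; beyond the scatter). The value of compound 3 is only a limit: the limit of > 200000 nM in this assay, at which 1 of the 3 values shown sits.

The compounds shown leave open whether the ring nitrogen alone accounts for these steps, a question that pyridin-2-yl without fluorine or 4-fluorophenyl on the same nitrogen would address.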